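Trimethoxyphenyl pyrazole chalcones: varying the aryl on the carbonyl

The source may report more compounds than this note shows. Statements on the series, on what has been measured and on what is new or still open speak of the compounds shown alone.

Measured so far:
compound 1 `COc1cc(-c2cc(/C=C/C(=O)c3ccc(Cl)c(Cl)c3)[nH]n2)cc(OC)c1OC`: -16%
compound 2 `COc1ccc(C(=O)/C=C/c2cc(-c3cc(OC)c(OC)c(OC)c3)n[nH]2)cc1OC`: -90%

In a functional assay on SK-MEL-28 cells (Homo sapiens) for cytotoxicity, read by sulforhodamine B assay, with a stated time of 48 h, tested at 100 uM (a higher number here means a weaker effect of the compound at the concentration tested, a lower number a stronger effect), compound 1 gives -16%, while compound 2 gives -90%. Among the measured compounds shown here, compound 2 stands lowest of the two numbers; its only neighbour is compound 1, and the step of a number 74 percentage points lower from compound 1 to compound 2 (beyond the scatter) is large and beyond the scatter. That step comes from 3,4-dimethoxyphenyl in place of 3,4-dichlorophenyl on a carbonyl carbon.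

Compound 3 `COc1cc(C(=O)/C=C/c2cc(-c3cc(OC)c(OC)c(OC)c3)n[nH]2)cc(OC)c1OC` is not yet measured. It differs from compound 2 by methoxy in place of hydrogen on an aromatic carbon, the new group sitting on an aromatic carbon of a six-membered aromatic ring of carbon only, ortho to a methoxy group, meta to a methoxy group and meta to a large group. For the measured compounds named here, no measured step tests the addition of a single methoxy group; the one step available, which swapped chlorines for methoxy groups on the same ring, was large and went downward. Compound 2 already stands far down, so the expected step of a number 5 percentage points higher from compound 2 to compound 3 (within the scatter) is small, none beyond the scatter. Compound 3 is therefore estimated at -85%, with a range from -100% to -55%.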

Compound 3, a percentage reported as activity, at one concentration (the size of the read-out at that concentration, not a potency): -97%
Estimate against measurement, compound 3: 12 percentage points above; the measured number falls inside the stated range.
By their numbers in this assay, from the lowest: compounds 3 and 2 (each within the scatter of the next); then compound 1.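

In this assay, methoxy in place of hydrogen on an aromatic carbon, ortho to a methoxy group and meta to a large group, gives a number 7 percentage points lower from compound 2 to compound 3 (within the scatter). Among the compounds shown here, this is the first reading of a single added group on this ring: where the exchange of chlorines for methoxy groups gave a number 74 percentage points lower from compound 1 to compound 2 (beyond the scatter), the added methoxy at this position leaves compound 2 and compound 3 without any order between them, so the position accepts the group with no loss of the effect at the one concentration tested. Nothing available explains either the large earlier step or the absence of a step here.

Because the read-out is taken at a single concentration and is not a potency, these numbers cannot tell whether compound 2 and compound 3 would separate at lower concentrations. On these data alone, it also remains open whether this position accepts groups other than methoxy, such as an amine, a carboxylic acid or a longer alkoxy chain, and whether a single chlorine there would move the number back toward that of compound 1.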